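Adding a fluoro group to the fused ring of compound 3

This account rests on a few compounds, and the source may have more. Where it says the series, first, only, none or still open, it means among the compounds named here.

Three compounds share a pyrazole-carboxamide core linked to a benzothiazole amine. Compound 1 `O=C(Nc1nc2ccc(F)cc2s1)c1cn(-c2ccccc2)nc1-c1ccc(F)cc1` gives 6650 nM in a functional assay on A549 cells (Homo sapiens) for cytotoxicity, read by MTT assay, with a stated time of 72 h; a higher number here means a weaker inhibitor, a lower number a stronger inhibitor. For the measured compounds named here, compound 2 `O=C(Nc1nc2ccc(F)cc2s1)c1cn(-c2ccccc2)nc1-c1ccc(Cl)cc1` gives 8860 nM in this assay, and the step of a 1.3-fold higher number from compound 1 to compound 2 (0.12 log units; within the scatter) is the only single-point change among the measured compounds. Compound 3 `COc1ccc(-c2nn(-c3ccccc3)cc2C(=O)Nc2nc3ccccc3s2)cc1` gives 13700 nM in this assay, the highest number of the three; its gap to compound 2 is within the scatter, whereas its gap to compound 1 is beyond it.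

Compound 4 `COc1ccc(-c2nn(-c3ccccc3)cc2C(=O)Nc2nc3ccc(F)cc3s2)cc1` is not yet measured. It differs from compound 3 by fluoro in place of hydrogen on an aromatic carbon. Going by the values given here, no measured step bears directly on this change: the only measured step concerns the other aryl ring, and compounds 1 and 2, which carry the fluoro group on the fused ring, also differ from compound 3 at the second aryl ring, so no clean comparison exists. The measured step from compound 1 to compound 2 was within the scatter, which suggests that single halogen changes on this scaffold are small. For compound 4 the number in this assay is therefore expected to stay close to that of compound 3, with the step of a 1.2-fold lower number from compound 3 to compound 4 (0.10 log units; within the scatter) estimated to lie within the scatter. Compound 4 is estimated at 11000 nM, in a range from 5000 nM to 25000 nM.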

Compound 4, half-maximal inhibitory concentration: 7560 nM
Compound 4: middle estimate off by 1.5-fold (0.16 log units), on the high side; measured number inside the range.
By their numbers in this assay, from the lowest: compounds 1, 4, 2 and 3 (each within the scatter of the next, the first and the last beyond it).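

The 6-fluoro-1,3-benzothiazol-2-yl group now has its first direct comparison with the unsubstituted 1,3-benzothiazol-2-yl group, with the methoxy-bearing aryl ring held constant: in this assay, the change gives a 1.8-fold lower number from compound 3 to compound 4 (0.26 log units; within the scatter) and so stays within the usual scatter. With fluoro held on the fused ring, the earlier halogen swap can also be extended to a group that is not a halogen, since a 1.2-fold lower number from compound 2 to compound 4 (0.07 log units; within the scatter) for methoxy in place of chloro and a 1.1-fold higher number from compound 1 to compound 4 (0.06 log units; within the scatter) for methoxy in place of fluoro both lie within the scatter, so these three substituents are not told apart in this assay. No evidence at hand accounts for any of these steps.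

Whether this position responds at all remains open, as fluoro is the only group shown there, and an amine, a carboxylic acid or a longer chain such as butoxy on the same aromatic carbon could give a step beyond the scatter. Also open, as far as these compounds go, is whether the small steps seen with these compounds would hold on cells other than the single line tested here.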